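This account rests on a few compounds, and the source may have more. Where it says the series, first, only, none or still open, it means among the compounds named here.

Series measured in a functional assay on SK-OV-3 cells (Homo sapiens) for antiproliferative activity, read by MTT assay, with a stated time of 72 h; on this read-out higher numbers stand for weaker inhibition and lower numbers for stronger inhibition:
- compound 1 `O=C(CCc1cccc2c1B(O)OC2)Nc1ccccc1`: 200 nM
- compound 2 `O=C(CCc1cccc2c1B(O)OC2)NCc1ccccc1`: > 100000 nM, a limit of the assay and not a number
- compound 3 `COc1ccccc1NC(=O)CCc1cccc2c1B(O)OC2`: 200 nM

Compound 3 stands level with compound 1, the nearest measured neighbour, and both sit far from the limit reached by compound 2.

The next step leads to compound 4 `C#Cc1ccccc1NC(=O)CCc1cccc2c1B(O)OC2`, which is still unmeasured. The change is ethynyl in place of methoxy on an aromatic carbon, ortho to a large group.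

For the measured compounds named here, only one measured step touches this place. Methoxy in place of hydrogen gave no change at the digits printed from compound 1 to compound 3 (within the scatter), within the scatter. The large step, an at least 500-fold higher number from compound 1 to compound 2 (2.69 log units; beyond the scatter), lies at the amide-type nitrogen, which the present change leaves untouched, so it bears only weakly here. Ethynyl itself has not been measured in this series, so some width is kept on both sides.

In this assay the expectation is therefore no step beyond the scatter, in either direction: no change at the digits printed from compound 3 to compound 4 (within the scatter) is the expected step. For compound 4 the estimated value is 200 nM, with an expected range from 60 nM to 800 nM.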

Compound 4, half-maximal inhibitory concentration: 820 nM
Estimate against measurement, compound 4: 4.1-fold (0.61 log units) below; the whole stated range lies below it.
By their numbers in this assay, from the lowest: compounds 1 and 3 (each within the scatter of the next); then compound 4. At a limit, above all of these: compound 2.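

In this assay, the aromatic carbon ortho to a large group proves sensitive to the choice of substituent, which the methoxy compound alone could not show: ethynyl gives a 4.1-fold higher number from compound 3 to compound 4 (0.61 log units; beyond the scatter), and against plain hydrogen it gives a 4.1-fold higher number from compound 1 to compound 4 (0.61 log units; beyond the scatter). Both steps are modest, so this place keeps the series in the same general range while still separating two groups of equal heavy-atom count, methoxy and ethynyl. Nothing measured on these compounds speaks to what lies behind this difference.

On these data alone, whether the higher number belongs to ethynyl alone or extends to other groups at this place, such as an amine, a nitrile or a carboxylic acid, remains open. Also open, as far as these compounds go, is whether ethynyl or methoxy would behave the same way elsewhere on this aromatic ring.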